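Sulfur to selenium on a fused aromatic core

The compounds below may be only part of what the source reports. "The series", "measured", "known", "first", "only" and "open" are said of these compounds alone.

Compound 1, `[SeH]c1nc2ccccc2s1`, is recorded in a functional assay on PC-3 cells (Homo sapiens) for cytotoxicity, read by MTT assay, with a stated time of 72 h (a higher number here means a weaker inhibitor of growth, a lower number a stronger inhibitor of growth), only as a limit, > 50000 nM.
Compound 2, `CSc1ccnc(SC)n1`, is recorded in this assay only as a limit, > 100000 nM.
Compound 3, `CSc1ccc2ccccc2n1`, is recorded in this assay only as a limit, > 100000 nM.

None of the three measured compounds gives a number in this assay. Compound 3 sits at the limit of > 100000 nM in this assay, at which 2 of the 3 values shown sit, while compound 1 sits at the limit of > 50000 nM in this assay, at which 1 of the 3 values shown sits. No pair of these compounds differs in a single place, so no measured step can be read from them, and nothing can be said about how a change at one position moves the read-out.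

The step from compound 3 to the unmeasured compound 4, `C[Se]c1ccc2ccccc2n1`, is a group of 2 heavy atoms (1 carbon, 1 selenium; no ring) in place of a group of 2 heavy atoms (1 carbon, 1 sulfur; no ring), on an aromatic carbon. Among the compounds with values here, both compounds share the same fused two-ring core, and the exchange touches only the single group on that aromatic carbon.

Within the data shown here, with compound 3 at a limit and no measured step of any kind available, the expectation for compound 4 rests on compound 3 alone. The step of a number no higher from compound 3 to compound 4 (the limit leaves the size open) is expected to show no change beyond the scatter, with a real chance that compound 4 again returns only a limit. Compound 4 is therefore estimated at 100000 nM, with a range from 30000 nM to 300000 nM.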

Compound 4, concentration for total growth inhibition: > 100000 nM
Compound 4 was reported as a limit; the forecaster's own chance of this, stated with the estimate: 70%; the middle value lies on the limit itself.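

Compound 3 and compound 4 are both recorded in this assay only as limits, so the exchange of methylsulfanyl for its selenium counterpart gives no readable step between them. The compounds shown leave open whether selenium in place of sulfur on this core changes growth inhibition at all, and whether any of them gives a number: the limit of > 100000 nM in this assay, at which 3 of the 4 values shown sit.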